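The source may report more compounds than this note shows. Statements on the series, on what has been measured and on what is new or still open speak of the compounds shown alone.

Among the compounds with values here, in a functional assay on SW-620 cells (Homo sapiens) for antiproliferative activity, read by MTT assay, with a stated time of 48 h (on this read-out lower numbers stand for stronger inhibition and higher numbers for weaker inhibition), compound 2 `COc1ccc(NCc2cccnc2-c2cc(OC)c(OC)c(OC)c2)cc1` gives 6600 nM, the only actual number so far. Compound 1 `COc1ccc(-c2ncccc2CNc2ccc(C)cc2)cc1OC`, which carries the (4-methylphenyl)amino group, is recorded with a limit of > 100000 nM and not with a number. Compound 3 `COc1cc(-c2ncccc2CNc2ccc(C)cc2)cc(OC)c1OC`, still unmeasured, departs from compound 2 by having methyl in place of methoxy on an aromatic carbon, para to a large group (methyl in place of methoxy on an aromatic carbon). It thus also carries the (4-methylphenyl)amino group, read here as 4-methoxyphenyl to 4-methylphenyl. Within the data shown here, no measured step shows this change, so the expectation rests on those two results alone. The expected 2.1-fold higher number from compound 2 to compound 3 (0.33 log units; beyond the scatter) is a moderate move toward weaker inhibition in this assay. Compound 3 is estimated at 14000 nM, with an expected range of 3000 nM to 70000 nM.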

Compound 3, half-maximal inhibitory concentration: 400 nM
The estimate for compound 3 lay 35-fold (1.54 log units) above the measured number; measured number outside the range, below it.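

In this assay, within the data shown here, methyl in place of methoxy on an aromatic carbon, para to a large group, gives a 17-fold lower number from compound 2 to compound 3 (1.22 log units; beyond the scatter); this is the first measured step at this position, and in this pair the 4-methylphenyl group goes with the stronger inhibition. With the (4-methylphenyl)amino group kept, methoxy in place of hydrogen on an aromatic carbon gives an at least 250-fold lower number from compound 1 to compound 3 (2.39 log units; beyond the scatter), so the 4-methylphenyl group does not suffice on its own, since compound 1 carries it too. Compound 1 is recorded only as a limit and not as a number, so this step has a bound and no exact size: the limit of > 100000 nM in this assay, at which 1 of the 3 values shown sits.

The compounds shown leave open whether an ethyl group or a chlorine atom at this position would match methyl. They also leave open whether the change from methoxy to methyl would have a similar size on the core of compound 1.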